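Series notes: the chain carbon substituent and growth inhibition

A few compounds are considered here, and "the series" means these few. Any claim that something is new, unique, unknown or untested is made for them only; others in the source may bear on it.

Measured so far, in a functional assay on G-361 cells (Homo sapiens) for cytotoxicity, read by sulforhodamine B assay; on this read-out lower numbers stand for stronger inhibition of growth and higher numbers for weaker inhibition of growth:
- compound 1, `Cc1nc(NC(C)C)c2cnn(-c3ccccc3)c2n1`: > 100000 nM (a limit of this assay)
- compound 2, `CCc1nc(NC(C)C)c2cnn(-c3ccccc3)c2n1`: > 100000 nM (a limit of this assay)
- compound 3, `CCCCNc1nc(CC)nc2c1cnn2-c1ccccc1`: 32000 nM

Compound 2 sits at the limit of this assay, which is the reading given for compound 2 alone. The same limit is returned for compound 1 (the limit of > 100000 nM in this assay, at which 2 of the 3 values shown sit). Only compound 3 gives a number in this assay. The step that the two limits leave unreadable from compound 1 to compound 2 is unreadable, as both ends are limits. The step of an at least 3.1-fold lower number from compound 2 to compound 3 (0.49 log units; beyond the scatter) is at least modest, but it changes the group on the ring nitrogen, not the chain carbon.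

The next compound, compound 4 `CC(C)NCc1nc(NC(C)C)c2cnn(-c3ccccc3)c2n1`, differs from compound 2 by isopropylamino in place of methyl on a saturated chain carbon bound to an aromatic carbon. For the measured compounds named here, no measured step bears on that place in a readable way: the one step at the chain carbon is the unreadable pair of limits. No direction can be drawn from the numbers shown.

The expectation for compound 4 is therefore a step of about a number no higher from compound 2 to compound 4 (the limit leaves the size open), that is, no change beyond the scatter that the data can support. Compound 4 is estimated at 100000 nM, in the range 30000 nM to 300000 nM, with a fair chance that this assay again reports only a limit.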

Compound 4, concentration for total growth inhibition: > 100000 nM
Compound 4 ended at the assay's limit; the forecaster's own chance of this, stated with the estimate: 55%; the middle value lies on the limit itself.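

In this assay, compound 1, compound 2 and compound 4 each return only a limit, so no step among these three can be read: the limit of > 100000 nM in this assay, at which 3 of the 4 values shown sit.

The compounds shown leave open whether any group on the saturated chain carbon bound to an aromatic carbon alters growth inhibition.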